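Adding a Methoxy Group to Compound 2

The compounds below may be only part of what the source reports. "The series", "measured", "known", "first", "only" and "open" are said of these compounds alone.

Two related compounds have been tested for their ability to kill mouse tumour cells. In a functional assay on Ehrlich cells (Mus musculus) for cytotoxicity, read by LDH release, with a stated time of 48 h (on this read-out higher numbers stand for weaker inhibition and lower numbers for stronger inhibition), compound 1 (`COc1ccc(-c2csc(NC(=O)COc3ccc(C(=O)c4ccccc4)cc3C)n2)cc1`) gives 28600 nM. In the same test, compound 2 (`Cc1ccc(C(=O)c2ccc(OCC(=O)Nc3nc(-c4ccccc4)cs3)c(C)c2)cc1`) gives 30500 nM. Compound 2 has the higher of the two numbers, but the gap lies within the usual scatter of repeated measurements, so the two cannot be told apart.

Compound 3 (`COc1ccc(-c2csc(NC(=O)COc3ccc(C(=O)c4ccc(C)cc4)cc3C)n2)cc1`) is built from compound 2 by a single change: methoxy in place of hydrogen on an aromatic carbon. In words, this is methoxy in place of hydrogen on an aromatic carbon, turning phenyl into 4-methoxyphenyl. Within the data shown here, no pair of measured compounds differs in only one place, so this change has no direct precedent here. Among the measured compounds shown here, the only guide is the close agreement of the two measured values, which gives no reason to predict a large shift. The estimated 1.1-fold lower number from compound 2 to compound 3 (0.02 log units; within the scatter) therefore stays within the scatter, with no firm direction expected. For compound 3 the expected value is 29000 nM, with an estimated range from 15000 nM to 58000 nM.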

Compound 3, half-maximal inhibitory concentration: 20900 nM
Beside the measured number, compound 3's estimate is 1.4-fold (0.14 log units) above it; the range from low to high includes it.
By their numbers in this assay, from the lowest: compounds 3, 1 and 2 (each within the scatter of the next).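

In this assay, among these compounds, turning phenyl into 4-methoxyphenyl gives a 1.5-fold lower number from compound 2 to compound 3 (0.16 log units; within the scatter) and so provides the first direct reading of this change: a methoxy group can take the place of hydrogen at this aromatic carbon without a shift that can be told apart from ordinary repeat-to-repeat variation. The second comparison, the addition of a methyl group, gives a 1.4-fold lower number from compound 1 to compound 3 (0.14 log units; within the scatter) and likewise leaves compound 3 indistinguishable from its neighbour, so neither single change separates the compounds in this test. No measurement here bears on why these small steps look as they do.

Going by these compounds, what remains open is whether any group at this position can move the number beyond the scatter, for example an amine, a carboxylic acid or a longer chain such as butoxy in place of the methoxy. Among the compounds shown here, it also remains unknown whether the methoxy group would behave the same way on a core carrying a different set of substituents, since these three compounds offer only one example of each change.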